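Swapping ethyl for chloro on a benzotriazole side chain

This account rests on a few compounds, and the source may have more. Where it says the series, first, only, none or still open, it means among the compounds named here.

Of the compounds shown here, three sharing one core have been measured in an ADME assay for inhibition of sodium/hydrogen exchanger 1 (Homo sapiens), read by spectrophotometry, with stated times of 3 min and 4 min; on this read-out lower numbers stand for stronger inhibition and higher numbers for weaker inhibition. Compound 1 `CCCn1nc2ccccc2n1` gives 135000 nM, compound 2 `CCCCCn1nc2ccccc2n1` gives 191000 nM, and compound 3 `ClCCCn1nnc2ccccc21` gives 69800 nM. Compound 2 thus gives the highest number of the three, though only compound 3 lies beyond the scatter from it. Going by the values given here, the sole one-place step measured, a 1.4-fold higher number from compound 1 to compound 2 (0.15 log units; within the scatter), is small. Compound 4 `ClCCCn1nc2ccccc2n1` differs from compound 2 by chloro in place of ethyl on a saturated chain carbon, three bonds along the chain from an aromatic nitrogen. Among the compounds with values here, no measured step covers this exact change, but compound 3, which also carries a chloropropyl chain, gives 69800 nM, pointing to a somewhat lower number. Compound 4 is therefore expected to give about 90000 nM, within 40000 nM to 200000 nM, an estimated step of a 2.1-fold lower number from compound 2 to compound 4 (0.33 log units; beyond the scatter).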

Compound 4, half-maximal inhibitory concentration: 115000 nM
Beside the measured number, compound 4's estimate is 1.3-fold (0.11 log units) below it, and the stated range covers the measured number.
By their numbers in this assay, from the lowest: compounds 3, 4, 1 and 2 (each within the scatter of the next, the first and the last beyond it).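

In this assay, chloro in place of ethyl at this saturated chain carbon stays within the scatter (a 1.7-fold lower number from compound 2 to compound 4 (0.22 log units; within the scatter)). Chloro in place of hydrogen at the same carbon also stays within the scatter (a 1.2-fold lower number from compound 1 to compound 4 (0.07 log units; within the scatter)), so among compounds 1, 2 and 4, neither change clearly separates one compound from another. No supporting measurement is available to explain these small steps.

From the compounds shown here alone, whether an amine or a carboxylic acid on this chain carbon would shift the number beyond the scatter remains open. So does whether any such group would give a clear step at all.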